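The compounds below may be only part of what the source reports. "The series", "measured", "known", "first", "only" and "open" are said of these compounds alone.

Working notes on the series.

Compound 1 `CC(C)CCn1ccc(N2CCC(c3ccccc3)CC2)c(C#N)c1=O` gives 102 nM in a functional assay on CHO cells for positive allosteric modulation of metabotropic glutamate receptor 2 (Homo sapiens), with a stated time of 30 min; a higher number here means that more compound is needed for the effect, a lower number that less compound is needed. Going by the values given here, compound 2 `N#Cc1c(N2CCC(c3cccc(F)c3)CC2)ccn(CC2CC2)c1=O`, which carries the 3-fluorophenyl and the cyclopropylmethyl, gives 141 nM in this assay, the highest of the three numbers so far; its nearest neighbour is compound 1, within the usual scatter, and its furthest is compound 3 `N#Cc1c(N2CCC(c3cccc(C(F)(F)F)c3)CC2)ccn(CC2CC2)c1=O`, which gives 46 nM. Among the compounds with values here, the one single-point step among the measured compounds is a 3.1-fold lower number from compound 2 to compound 3 (0.49 log units; beyond the scatter), a modest gain that sits at the same saturated ring carbon as the change considered next.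

Compound 4 `COc1ccc(C2CCN(c3ccn(CC4CC4)c(=O)c3C#N)CC2)cc1` differs from compound 2 in one place: 4-methoxyphenyl in place of 3-fluorophenyl on a saturated ring carbon. Within the data shown here, no measured step swaps the aromatic substituent for a methoxy or moves it from the position of the fluoro to that of the methoxy, so the step from compound 2 to compound 3 bears on it only by place, not by kind of group. With nothing to anchor a direction, the expectation for compound 4 is a number near that of compound 2, with any difference likely within the scatter, i.e. an expected step of a 1.1-fold higher number from compound 2 to compound 4 (0.03 log units; within the scatter). Compound 4 is therefore estimated at 150 nM in this assay, with a range from 55 nM to 420 nM.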

Compound 4, half-maximal effective concentration: 98 nM
For compound 4 the middle estimate is 1.5-fold (0.18 log units) above the measured one; the measured number falls inside the stated range.
By their numbers in this assay, from the lowest: compound 3; then compounds 4, 1 and 2 (each within the scatter of the next).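

The step of a 1.4-fold lower number from compound 2 to compound 4 (0.16 log units; within the scatter) in this assay stays within the scatter, so at this saturated ring carbon the 3-fluorophenyl can give way to 4-methoxyphenyl, a change of both the substituent and its place on the aromatic ring, without a readable shift in the number. Set against a 3.1-fold lower number from compound 2 to compound 3 (0.49 log units; beyond the scatter), the only earlier step at this place, it shows that the number does not move with every replacement on the aromatic ring: here a group with one hydrogen-bond acceptor enters for one with none, and no shift beyond the scatter follows. Nothing measured on these compounds bears on why the two steps differ in size.

As far as these compounds go, the swap from compound 2 to compound 4 changes the substituent and its place together, so the contribution of each stays open. Also open, from the compounds shown here alone, is how this assay would read with an amine or a carboxylic acid on the aromatic ring, groups that would show whether this place accepts more than the fluoro, trifluoromethyl and methoxy seen so far.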